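Butyl to tert-butyl on the shared core

The source may report more compounds than this note shows. Statements on the series, on what has been measured and on what is new or still open speak of the compounds shown alone.

Measured values in a functional assay (aorta) with Rattus norvegicus as the target; on this read-out lower numbers stand for stronger inhibition and higher numbers for weaker inhibition
- compound 1 `CC(C)(C)NCCCOc1ccc(S(=O)(=O)c2c(C(C)(C)C)cn3ccccc23)cc1` gives 443 nM
- compound 2 `CCCCc1cn2ccccc2c1S(=O)(=O)c1ccc(OCCCN(CCC)CCC)cc1` gives 570 nM
- compound 3 `CCCCc1cn2ccccc2c1S(=O)(=O)c1ccc(OCCCN(CCCC)CCCC)cc1` gives 284 nM

Compound 3 at 284 nM lies within the scatter of both compound 1 and compound 2. Compound 4 `CCCCN(CCCC)CCCOc1ccc(S(=O)(=O)c2c(C(C)(C)C)cn3ccccc23)cc1` keeps the dibutylamino chain of compound 3 and differs from it as follows: tert-butyl in place of butyl on an aromatic carbon. Going by the values given here, no measured step makes this exchange. Among the compounds with values here, the only step available, a 2.0-fold lower number from compound 2 to compound 3 (0.30 log units; within the scatter), concerns the amine and stays within the scatter. Compound 1 , which also carries tert-butyl, gives 443 nM and so shows no separation from compound 3 in this assay on the values alone. No step beyond the scatter is therefore expected, and the estimated step is a 1.1-fold higher number from compound 3 to compound 4 (0.05 log units; within the scatter) in size. For compound 4 the expected value is 320 nM, with an estimated range of 120 nM to 850 nM.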

Compound 4, half-maximal inhibitory concentration: 51.9 nM
Beside the measured number, compound 4's estimate is 6.2-fold (0.79 log units) above it, outside the stated range (below it).
By their numbers in this assay, from the lowest: compound 4; then compounds 3, 1 and 2 (each within the scatter of the next).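

In this assay, going by these compounds alone, tert-butyl in place of butyl on an aromatic carbon gives a 5.5-fold lower number from compound 3 to compound 4 (0.74 log units; beyond the scatter) and is the first exchange at this position to be read directly, with both groups holding the same count of heavy atoms. With tert-butyl held, dibutylamino in place of (tert-butyl)amino gives an 8.5-fold lower number from compound 1 to compound 4 (0.93 log units; beyond the scatter) and shows that the amine end also moves the number on this core. No available data account for either step.

Open, as far as these compounds go, is whether isopropyl or cyclopropyl at this position would follow tert-butyl or butyl. Also open, from the compounds shown here alone, is whether dipropylamino paired with tert-butyl would track dibutylamino.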